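The source may hold more compounds than are shown below. What is called first, only, known or untested is meant among the compounds shown, and "the series" means these compounds.

Compound 2 `CC(C)[C@H](C(=O)Nc1nncs1)c1ccc(Cl)cc1` stands highest of the two numbers in a functional assay on CHO cells for agonist activity at Free fatty acid receptor 2 (Homo sapiens), read by cAMP accumulation (a lower number here means a stronger inhibitor, a higher number a weaker inhibitor), giving 12000 nM. For the measured compounds named here, its nearest neighbour, compound 1 `CC(C)[C@H](C(=O)Nc1ccc(F)cn1)c1ccc(Cl)cc1`, gives 1300 nM in this assay, and the single measured step, a 9.2-fold higher number from compound 1 to compound 2 (0.97 log units; beyond the scatter), exchanges the 5-fluoropyridin-2-yl group for the 1,3,4-thiadiazol-2-yl group on the amide-type nitrogen. Compound 3 `CC(C)[C@H](C(=O)Nc1ncns1)c1ccc(Cl)cc1` differs from compound 2 by 1,2,4-thiadiazol-5-yl in place of 1,3,4-thiadiazol-2-yl on an amide-type nitrogen. Going by the values given here, no measured step bears directly on this change: the one step on record replaces a pyridinyl with a thiadiazolyl group, whereas here one thiadiazolyl isomer replaces another, with the same atoms joined differently. Among the compounds with values here, with no direct precedent, the expectation rests on the observation that both compounds carry a thiadiazolyl ring in the same place, so the step from compound 2 to compound 3 is estimated to be a 1.2-fold lower number from compound 2 to compound 3 (0.08 log units; within the scatter), no larger than the usual scatter. Compound 3 is therefore expected to give about 10000 nM in this assay, with a range from 3000 nM to 30000 nM.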

Compound 3, half-maximal inhibitory concentration: 2000 nM
Beside the measured number, compound 3's estimate is 5.0-fold (0.70 log units) above it; measured number below the stated range.
By their numbers in this assay, from the lowest: compounds 1 and 3 (each within the scatter of the next); then compound 2.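

In this assay, the group on the amide-type nitrogen turns out to be sensitive to how the same atoms are joined: a 6.0-fold lower number from compound 2 to compound 3 (0.78 log units; beyond the scatter) is a step beyond the scatter, although the 1,3,4-thiadiazol-2-yl and 1,2,4-thiadiazol-5-yl groups match in every count of atoms, donors and acceptors. The step of a 1.5-fold higher number from compound 1 to compound 3 (0.19 log units; within the scatter) lies within the scatter, so among the compounds shown the thiadiazolyl ring as such does not carry the higher number of compound 2, which belongs to that one isomer alone. No measurement on hand explains why the two isomers differ.

The compounds shown leave open whether this sensitivity extends to other five-membered rings, such as a 1,3,4-oxadiazol-2-yl group in the same place. They also leave open how a methyl group or an amine carried on the 1,2,4-thiadiazol-5-yl ring would read.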